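Methoxy Position Shift and Antiproliferative Potency

The compounds below may be only part of what the source reports. "The series", "measured", "known", "first", "only" and "open" are said of these compounds alone.

For the measured compounds named here, compound 2 `CNc1nc(Nc2ccc(C)c([N+](=O)[O-])c2)ncc1C(=O)Nc1cc(NC(=O)c2cccc(OC)c2)ccc1C` is the only compound here with a plain number in an ADME assay on BaF3 cells (Mus musculus) for antiproliferative activity, read by CellTiter-Glo and CCK-8 assay, with a stated time of 72 h; a lower number here means a stronger inhibitor of growth, a higher number a weaker inhibitor of growth: in this assay compound 2 gives 6310 nM. Compound 1 `CNc1nc(Nc2ccc(C)c([N+](=O)[O-])c2)ncc1C(=O)Nc1cc(NC(=O)c2ccccc2OC)ccc1C` reaches only a limit of the assay, > 10000 nM, which is the limit of > 10000 nM in this assay, at which 1 of the 2 values shown sits. Going by the values given here, the single measured step, an at least 1.5-fold lower number from compound 1 to compound 2 (0.19 log units; that floor lies within the scatter), therefore has a floor but no firm size. Compound 3 `CNc1nc(Nc2ccc(C)c([N+](=O)[O-])c2)ncc1C(=O)Nc1cc(NC(=O)c2ccc(OC)cc2)ccc1C` carries the change (4-methoxyphenyl in place of 3-methoxyphenyl on a carbonyl carbon). Among the compounds with values here, only that one step, moving the same methoxy on the same carbonyl carbon, bears on it, and its floor is small, so no step beyond the scatter is expected, a 1.3-fold lower number from compound 2 to compound 3 (0.10 log units; within the scatter). Compound 3 is estimated at 5000 nM, with a range from 2000 nM to 15000 nM.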

Compound 3, concentration for 50% growth inhibition: > 10000 nM
Compound 3 was reported as a limit; the forecaster's own chance of this, stated with the estimate: 30%; middle value at least 2.0-fold (0.30 log units) away from the limit.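

Moving the methoxy from 3-methoxyphenyl to 4-methoxyphenyl on this carbonyl carbon gives an at least 1.5-fold higher number from compound 2 to compound 3 (0.19 log units; that floor lies within the scatter) in this assay, so this step's floor, like that of the earlier step, cannot show a change beyond the scatter. Of the three methoxy positions, only compound 2 has a plain number, and the value of compound 3 is a limit, which it now shares with compound 1: the limit of > 10000 nM in this assay, at which 2 of the 3 values shown sit. The step between those two limits cannot be read.

Open remain how far the true values of compound 1 and compound 3 lie past the limit, and how an amine, a carboxylic acid or a longer chain in place of the methoxy would read.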